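Replacing isopentyl with 4-fluorobenzyl in compound 1

This account rests on a few compounds, and the source may have more. Where it says the series, first, only, none or still open, it means among the compounds named here.

Among the compounds with values here, in a functional assay on HepG2 cells (Homo sapiens) for inhibition, read by MTT assay, with a stated time of 72 h (on this read-out higher numbers stand for weaker inhibition and lower numbers for stronger inhibition), compound 1 (`CC(C)CCN(CCCCCCC(=O)NO)c1ncc(C(=O)NCc2cccnc2)s1`) gives 7000 nM as the lowest of three numbers so far, against compound 2 (`CC(C)CCN(CCCCCCC(=O)NO)c1ncc(C(=O)NCCCn2ccnc2)s1`) with 24000 nM and compound 3 (`O=C(NO)c1ccc(CN(Cc2ccc(F)cc2)c2ncc(C(=O)NCCCn3ccnc3)s2)cc1`) with 79000 nM. Compound 4 (`O=C(CCCCCCN(Cc1ccc(F)cc1)c1ncc(C(=O)NCc2cccnc2)s1)NO`) keeps the rest of compound 1 and brings 4-fluorophenyl in place of isobutyl on a saturated chain carbon bound to a nitrogen on an aromatic ring. Within the data shown here, the only measured step (a 3.4-fold higher number from compound 1 to compound 2 (0.54 log units; beyond the scatter)) lies at a different place, on a saturated chain carbon bound to an amide-type nitrogen, so it offers a rough size and no direct reading. Compound 2 and compound 3 differ in more than the 4-fluorobenzyl group, so the number for compound 3 (79000 nM) cannot be assigned to that group alone. The estimated step in this assay is a 1.4-fold higher number from compound 1 to compound 4 (0.15 log units; within the scatter) and leans toward a higher number. For compound 4 the expected value is 10000 nM (estimated range 3000 nM to 35000 nM).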

Compound 4, half-maximal inhibitory concentration: 14000 nM
Compound 4: middle estimate off by 1.4-fold (0.15 log units), on the low side, within the range that was stated.
By their numbers in this assay, from the lowest: compounds 1, 4 and 2 (each within the scatter of the next, the first and the last beyond it); then compound 3.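

In this assay, within the data shown here, the exchange of isopentyl for 4-fluorobenzyl gives a 2.0-fold higher number from compound 1 to compound 4 (0.30 log units; within the scatter) and so is the first one-place reading at this position, on a saturated chain carbon bound to a nitrogen on an aromatic ring. The step from isobutyl to 4-fluorophenyl brings in a six-membered aromatic ring of carbon only, and its size stays within the usual scatter of this read-out. No measured evidence bears on this result, so the step remains a plain observation.

Still open, going by these compounds, is how this position responds to a group such as unsubstituted benzyl or a chain ending in an amine or a carboxylic acid. Also open, on these data alone, is whether 4-fluorobenzyl gives a similar step when compound 2 is the starting point.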